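Exchanging an aromatic amine arm for a chain

The source may hold more compounds than are shown below. What is called first, only, known or untested is meant among the compounds shown, and "the series" means these compounds.

Compound 1 `Nc1cccc(Nc2c(C(=O)NCc3ccc(F)cc3)nc(Br)c3cccnc23)c1` is one of two compounds in this set with a measured cytotoxicity number. In a functional assay on MCF7 cells (Homo sapiens) for cytotoxicity, read by MTT assay, with a stated time of 72 h (a lower number here means a stronger inhibitor, a higher number a weaker inhibitor), compound 1 gives 8000 nM, which is the higher of the two values in hand. Its nearest neighbour, compound 3 `N[C@H]1CC[C@H](Nc2c(C(=O)NC3CCCCC3)nc(Br)c3cccnc23)CC1`, gives 5200 nM in this assay, and the gap between the two lies within the usual scatter, so neither can be called the stronger inhibitor. A third member, compound 2 `C[C@H](CO)Nc1nc(C(=O)NCc2ccc(F)cc2)c(O)c2ncccc12`, carries "not determined" (no result reported) in this assay and so brings no number to the comparison.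

Compound 4 `NCCCCCCNc1c(C(=O)NCc2ccc(F)cc2)nc(Br)c2cccnc12` is the unmeasured partner of compound 1. The change between them is 6-aminohexyl in place of 3-aminophenyl on a nitrogen on an aromatic ring. For the measured compounds named here, no measured pair in this set shows that exchange, so there is no step to lean on beyond the two numbers already given. The step of a 1.2-fold lower number from compound 1 to compound 4 (0.09 log units; within the scatter) is therefore expected to be modest, with no clear direction, and most likely not beyond the scatter. Compound 4 is expected to come in near 6500 nM, with a plausible range from 2000 nM to 20000 nM.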

Compound 4, half-maximal inhibitory concentration: 2000 nM
Estimate against measurement, compound 4: 3.3-fold (0.51 log units) above; the range from low to high includes it.
By their numbers in this assay, from the lowest: compound 4; then compounds 3 and 1 (each within the scatter of the next).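

For the compounds shown here, the exchange of 3-aminophenyl for 6-aminohexyl on a nitrogen on an aromatic ring gives a 4.0-fold lower number from compound 1 to compound 4 (0.60 log units; beyond the scatter) in this assay, the only step so far between compounds that differ in one place, and it shows that the number responds to what sits at this position. Going by these compounds alone, the two groups match in heavy atoms, hydrogen-bond donors, hydrogen-bond acceptors and net charge, while the six-membered aromatic ring of the leaving group has no counterpart in the open chain that enters. Nothing measured here accounts for the difference.

Going by these compounds, it remains open whether the lower number follows from losing the ring or from the length of the chain, which a shorter aminobutyl chain or a longer aminooctyl chain would address. Nor do these compounds show whether the terminal amine matters, as a hexyl chain ending in a hydroxyl group would test.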